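A few compounds are considered here, and "the series" means these few. Any claim that something is new, unique, unknown or untested is made for them only; others in the source may bear on it.

Measured compounds:
Compound 1, `COCn1c(CC(COCc2ccccc2)COCc2ccccc2)cc(=O)[nH]c1=O`, in a functional assay on MIA PaCa-2 cells (Homo sapiens) for antiproliferative activity, read by MTT assay, with a stated time of 72 h (a higher number here means a weaker inhibitor, a lower number a stronger inhibitor), sits at the assay limit of > 100000 nM.
Compound 2, `COCn1c(CC(COCc2ccccc2)COCc2ccccc2)c(C)c(=O)[nH]c1=O`, in this assay gives 55900 nM.
Compound 3, `C[Si](C)(C)CCOCn1c(CC(O)CO)cc(=O)[nH]c1=O`, in this assay sits at the assay limit of > 100000 nM.

Compound 1 and compound 3 share a core, and the difference between the two cores is not broken down here. Between compound 1 and compound 2 the change is methyl in place of hydrogen on an aromatic carbon, and it made an at least 1.7-fold lower number from compound 1 to compound 2 (0.25 log units; that floor lies within the scatter); the size of that step is bounded by the limit of > 100000 nM in this assay, at which 2 of the 3 values shown sit.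

Compound 4, `Cc1c(CC(O)CO)n(COCC[Si](C)(C)C)c(=O)[nH]c1=O`, stands to compound 3 as compound 2 stands to compound 1. The change is methyl in place of hydrogen on an aromatic carbon. It is the same kind of change, yet the surroundings differ: in compound 4 the methyl is ortho to a 2,3-dihydroxypropyl group and meta to a group of 8 heavy atoms, where in compound 2 it is ortho to a large group and meta to a methoxymethyl group.

In this assay compound 4 is expected to give 80000 nM, estimated to fall between 35000 nM and 200000 nM. The expected step is an at least 1.2-fold lower number from compound 3 to compound 4 (0.09 log units; that floor lies within the scatter), a modest shift that rests on the earlier change having given only an at least 1.7-fold lower number from compound 1 to compound 2 (0.25 log units; that floor lies within the scatter).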

Compound 4, half-maximal inhibitory concentration: > 100000 nM
Compound 4 was reported as a limit; the forecaster's own chance of this, stated with the estimate: 55%; middle value at least 1.2-fold (0.09 log units) from the limit.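

No step can be read from compound 3 to compound 4, since both values in this assay are limits and not numbers: the limit of > 100000 nM in this assay, at which 3 of the 4 values shown sit.

The compounds shown leave open whether methyl in place of hydrogen on an aromatic carbon changes the number at all when the 2,3-dihydroxypropyl group is present.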